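Swapping the aryl group on the piperazine of compound 3

A few compounds are considered here, and "the series" means these few. Any claim that something is new, unique, unknown or untested is made for them only; others in the source may bear on it.

Measured compounds:
Compound 1 `COc1ccccc1N1CCN(CC(=O)NC2CCCc3c(OC)cccc32)CC1`: > 1000 nM
Compound 2 `COc1ccc2c(c1)CCCC2NC(=O)CCCCN1CCN(c2ccccc2OC)CC1`: 43.1 nM
Compound 3 `COc1ccc(OC)c(N2CCN(CCCCCC(=O)NC3CCCc4ccccc43)CC2)c1`: 70.3 nM

In an assay on HEK293 cells for displacement of a labelled ligand from 5-hydroxytryptamine receptor 7 (Rattus norvegicus) (on this read-out lower numbers stand for stronger inhibition and higher numbers for weaker inhibition), compound 3 gives 70.3 nM. Compound 2 gives 43.1 nM in this assay, and its value and that of compound 3 lie within the scatter of each other. For compound 1 the assay reports only a limit, > 1000 nM, not a number (the limit of > 1000 nM in this assay, at which 1 of the 3 values shown sits).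

Compound 4 `NC(=O)c1ccccc1N1CCN(CCCCCC(=O)NC2CCCc3ccccc32)CC1` differs from compound 3 in one place: 2-carbamoylphenyl in place of 2,5-dimethoxyphenyl on an amine nitrogen in a ring. Going by the values given here, no measured pair shows this change, so its effect is unknown. A moderate move toward a higher number is expected, a 2.8-fold higher number from compound 3 to compound 4 (0.45 log units; beyond the scatter), though a step within the scatter is also possible. Compound 4 is estimated at 200 nM, with a likely range from 50 nM to 1500 nM.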

Compound 4, inhibition constant: 229 nM
Estimate against measurement, compound 4: 1.1-fold (0.06 log units) below; the range from low to high includes it.
By their numbers in this assay, from the lowest: compounds 2 and 3 (each within the scatter of the next); then compound 4. At a limit, above all of these: compound 1.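

Going by these compounds alone, until now, no measured pair differed at this place, so this is the first direct reading of it. In this assay, 2-carbamoylphenyl in place of 2,5-dimethoxyphenyl on an amine nitrogen in a ring gives a 3.3-fold higher number from compound 3 to compound 4 (0.51 log units; beyond the scatter), which shows that the number responds to the aryl group at this position. No measurement shown explains this step.

As far as these compounds go, this single swap removes two methoxy groups and adds a carbamoyl group, so their separate contributions stay unknown. From the compounds shown here alone, how an unsubstituted phenyl or a 2-pyridyl group would read at this place also remains open.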